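Chalcone series on the shared core: dichlorophenyl step

The source may hold more compounds than are shown below. What is called first, only, known or untested is meant among the compounds shown, and "the series" means these compounds.

Working notes on a set of chalcones built on the core of compound 1, which has the structure `COc1ccc(C(=O)/C=C/c2cc(OC)c(OC)c(OC)c2)c2c1C=CC(C)(C)O2`. In a functional assay on K562 cells (Homo sapiens) for antiproliferative activity, read by MTT assay, with a stated time of 24 h (on this read-out lower numbers stand for stronger inhibition and higher numbers for weaker inhibition), compound 1 gives only a limit, > 10000 nM. Compound 2, of structure `COc1ccc(C(=O)/C=C/c2cccc(F)c2)c2c1C=CC(C)(C)O2`, carries a 3-fluorophenyl group; in this assay compound 2 likewise gives only a limit, > 10000 nM. Compound 3, of structure `COc1ccc(C(=O)/C=C/c2ccc(OC)c(OC)c2OC)c2c1C=CC(C)(C)O2`, also gives only a limit in this assay, > 10000 nM. All three measured compounds therefore sit at the same point, as summarised in the limit of > 10000 nM in this assay, at which 3 of the 3 values shown sit, and no comparison between them can be drawn from the numbers shown; compound 2 stands with the others at the limit.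

Compound 4, of structure `COc1ccc(C(=O)/C=C/c2ccc(Cl)c(Cl)c2)c2c1C=CC(C)(C)O2`, is not yet measured. Its difference from compound 2 is 3,4-dichlorophenyl in place of 3-fluorophenyl on a double-bonded chain carbon bound to a double-bonded chain carbon. Among the compounds with values here, no measured step is available for this change in this assay, so the direction cannot be anchored; with every measured compound at the limit, the expectation is that compound 4 will also most likely return a limit, with only a modest chance of a measurable number. The step from compound 2 to compound 4 is expected to be a step that the limit leaves unreadable from compound 2 to compound 4, meaning none beyond the scatter. For compound 4 the estimate is 12000 nM, within a range from 3000 nM to 40000 nM.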

Compound 4, half-maximal inhibitory concentration: 9030 nM
The estimate for compound 4 lay 1.3-fold (0.12 log units) above the measured number, within the range that was stated.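

With 3,4-dichlorophenyl in place of 3-fluorophenyl on a double-bonded chain carbon bound to a double-bonded chain carbon, this assay records an at least 1.1-fold lower number from compound 2 to compound 4 (0.04 log units; that floor lies within the scatter). Compound 4 gives the first number in the set rather than a limit, so this position is now shown to hold a group that yields a readable value, though the step itself does not establish a real difference. The other compounds remain where they were: the limit of > 10000 nM in this assay, at which 3 of the 4 values shown sit.

The size of the gap between compound 2 and compound 4 stays unknown, and the compounds shown cannot separate the exchange of fluorine for chlorine from the presence of a second halogen. Also open, going by these compounds, is how this assay would respond to a dimethylamino group or a carboxylic acid on the same phenyl ring.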